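Swapping the thiophene for a fluorinated phenyl ring

A few compounds are considered here, and "the series" means these few. Any claim that something is new, unique, unknown or untested is made for them only; others in the source may bear on it.

Measured in a functional assay on KYSE-70 cells for antiproliferative activity against KYSE-70 cell line (Homo sapiens), read by MTT assay, with a stated time of 72 h; on this read-out higher numbers stand for weaker inhibition and lower numbers for stronger inhibition:
- Compound 1 `O=C(Nc1cccc(F)c1)c1cc(=O)[nH]c2cc(Br)ccc12`: 8900 nM
- Compound 2 `O=C(Nc1cccc(F)c1)c1cc(=O)[nH]c2cc(-c3ccccc3)ccc12`: > 20000 nM, which is a limit of the assay and not a number
- Compound 3 `O=C(Nc1cccc(F)c1)c1cc(=O)[nH]c2cc(-c3ccsc3)ccc12`: 5100 nM

Only two of these results are true numbers, and they do not separate: a 1.7-fold lower number from compound 1 to compound 3 (0.24 log units; within the scatter). Compound 3 therefore stands level with the bromo compound, within the scatter.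

The next compound is compound 4 `O=C(Nc1cccc(F)c1)c1cc(=O)[nH]c2cc(-c3ccccc3F)ccc12`, which changes the ring attached to the shared core: 2-fluorophenyl in place of thiophen-3-yl on an aromatic carbon. In short, 2-fluorophenyl sits in place of thiophen-3-yl.

Within the data shown here, two measured steps bear on this. Replacing bromo with phenyl moved the number up: an at least 2.2-fold higher number from compound 1 to compound 2 (0.35 log units; beyond the scatter). The direct comparison of the two rings was larger: an at least 3.9-fold lower number from compound 2 to compound 3 (0.59 log units; beyond the scatter). Both are minimum sizes, since compound 2 sits at the limit of > 20000 nM in this assay, at which 1 of the 3 values shown sits.

Compound 4 returns to a six-membered ring, so part of that second step may be reversed. Among the measured compounds shown here, no compound here measures what the added fluorine does, which keeps the range wide. A modest move to a higher number is expected, and another limit is possible.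

For compound 4 the estimate is 14000 nM, with an expected range of 6000 nM to 30000 nM. The estimated change is a 2.7-fold higher number from compound 3 to compound 4 (0.44 log units; beyond the scatter).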

Compound 4, half-maximal inhibitory concentration: > 20000 nM
Compound 4: no number, only a limit; the forecaster's own chance of this, stated with the estimate: 40%; middle value at least 1.4-fold (0.15 log units) away from the limit.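

The result for compound 4 in this assay is a limit of the assay and not a number, so the steps that reach it give only minimum sizes. Putting 2-fluorophenyl at this position gives an at least 3.9-fold higher number from compound 3 to compound 4 (0.59 log units; beyond the scatter) when it replaces thiophen-3-yl, and an at least 2.2-fold higher number from compound 1 to compound 4 (0.35 log units; beyond the scatter) when it replaces bromo. A second six-membered aromatic ring of carbon only therefore falls on the weak side of thiophen-3-yl, so the gap seen with compound 2 is not confined to plain phenyl, and the step between compound 2 and compound 4 cannot be read because both compounds sit at the same limit: the limit of > 20000 nM in this assay, at which 2 of the 4 values shown sit.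

The compounds shown leave open whether fluoro on the phenyl ring changes the activity at all, and whether a ring that starts from a real number at this position would show it. They also leave open whether the advantage of compound 3 belongs to the five-membered ring or to its sulfur atom, which a furan-3-yl or pyridin-3-yl group, or an amine on the ring, could begin to test.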